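Swapping a chlorophenyl for a dimethylphenyl on the nitrogen

The compounds below may be only part of what the source reports. "The series", "measured", "known", "first", "only" and "open" are said of these compounds alone.

Two measured compounds share one core and differ only in the ring attached to an amide-type nitrogen. Compound 1 `CNC(=O)c1ccc(Oc2cccc(NC(=S)Nc3ccc(C)cc3)c2)nc1` carries a 4-methylphenyl there; in a functional assay on PC-3 cells (Homo sapiens) for antiproliferative activity, read by MTT assay (a lower number here means a stronger inhibitor, a higher number a weaker inhibitor), compound 1 gives > 100000 nM, which is a limit of the assay rather than a number (the limit of > 100000 nM in this assay, at which 1 of the 2 values shown sits). Compound 2 `CNC(=O)c1ccc(Oc2cccc(NC(=S)Nc3ccc(Cl)cc3)c2)nc1` carries a 4-chlorophenyl, and in this assay compound 2 gives 28400 nM. The step of an at least 3.5-fold lower number from compound 1 to compound 2 (0.54 log units; beyond the scatter) is the only measured change, and compound 2 holds the only real number shown. Compound 3 `CNC(=O)c1ccc(Oc2cccc(NC(=S)Nc3ccc(C)c(C)c3)c2)nc1` is not yet measured; it differs from compound 2 by 3,4-dimethylphenyl in place of 4-chlorophenyl on an amide-type nitrogen. The measured step bears on this only partly: trading methyl for chloro on that ring gave a better number, so returning to methyl groups is expected to cost potency. The estimated step of a 2.8-fold higher number from compound 2 to compound 3 (0.45 log units; beyond the scatter) therefore points toward a weaker compound. Compound 3 is expected to give about 80000 nM, between 20000 nM and 300000 nM.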

Compound 3, half-maximal inhibitory concentration: 67400 nM
Estimate against measurement, compound 3: 1.2-fold (0.07 log units) above; measured number inside the range.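

In this assay, the step of a 2.4-fold higher number from compound 2 to compound 3 (0.38 log units; beyond the scatter) shows that a ring with two methyl groups does not match the 4-chlorophenyl ring on this nitrogen. Compound 2 therefore remains the strongest of the three, now ahead of both methyl-bearing rings rather than just one. The step of an at least 1.4-fold lower number from compound 1 to compound 3 (0.17 log units; that floor lies within the scatter) shows what the added methyl does only as a floor, and it supports no claim of a gain, since compound 1 carries a limit of the assay and not a number: the limit of > 100000 nM in this assay, at which 1 of the 3 values shown sits.

The compounds shown leave open whether the gain belongs to chlorine in particular or would also appear with a 4-bromophenyl or 4-fluorophenyl ring. They also leave open whether a 3,4-dichlorophenyl ring on this nitrogen would lower the number further.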